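The compounds below may be only part of what the source reports. "The series", "measured", "known", "first", "only" and "open" are said of these compounds alone.

Compound 1 `Cc1c(C(=O)NCCCN2CCN(C)CC2)c(-c2cccc(N3CCN(c4ccc(C(=O)NS(=O)(=O)c5ccc(N[C@H](CCN(C)C)CSc6ccccc6)c([N+](=O)[O-])c5)cc4)CC3)c2)c(-c2ccc(Cl)cc2)n1C`: > 10000 nM (a limit)
Compound 2 `CCn1c(C)c(C(=O)O)c(-c2cccc(N3CCN(c4ccc(NS(=O)(=O)c5ccc(N[C@H](CCN(C)C)CSc6ccccc6)c([N+](=O)[O-])c5)cc4)CC3)c2)c1-c1ccc(Cl)cc1`: 4.5 nM

Both compounds were tested in a functional assay on NCI-H1963 cells (Homo sapiens) for antiproliferative activity, read by WST assay, with a stated time of 4 days; on this read-out higher numbers stand for weaker inhibition and lower numbers for stronger inhibition. The entry for compound 1 is a limit of the assay and not a number. Within the data shown here, compound 2 therefore holds the only true number, 4.5 nM. Compound 3 `Cc1c(C(=O)O)c(-c2cccc(N3CCN(c4ccc(NS(=O)(=O)c5ccc(N[C@H](CCN(C)C)CSc6ccccc6)c([N+](=O)[O-])c5)cc4)CC3)c2)c(-c2ccc(Cl)cc2)n1C1CC1` matches compound 2 except for one swap, cyclopropyl in place of ethyl on an aromatic nitrogen. Among the measured compounds shown here, no measured pair shows what a change at this place does, so the expectation in this assay is no step beyond the scatter, in either direction. The estimated change is a 1.1-fold higher number from compound 2 to compound 3 (0.05 log units; within the scatter). For compound 3 the estimate is 5 nM, with an expected range from 1.5 nM to 18 nM.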

Compound 3, half-maximal inhibitory concentration: 60 nM
Estimate against measurement, compound 3: 12-fold (1.08 log units) below, outside the stated range (above it).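

On the aromatic nitrogen of the shared core, the group matters: in this assay, cyclopropyl in place of ethyl gives a 13-fold higher number from compound 2 to compound 3 (1.12 log units; beyond the scatter). Even a swap between two small carbon-only groups, neither with a hydrogen-bond donor, an acceptor or a net charge, clearly weakens inhibition here. Nothing in the data shown explains the size of this step.

From the compounds shown here alone, only these two groups can be compared at this nitrogen, so it stays open whether the ring or the extra carbon matters. An isopropyl or a cyclobutyl group here could separate the two.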